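From Ethyl Ester to Phenyl Ketone on a Shared Core

The source may hold more compounds than are shown below. What is called first, only, known or untested is meant among the compounds shown, and "the series" means these compounds.

Measured so far:
compound 1 `CC(=O)/C=C1\C[C@H]2SC(C)(C)[C@H](C(=O)OC(c3ccccc3)c3ccccc3)N2C1=O` — > 100000 nM
compound 2 `CC1(C)[C@H](C(=O)OC(c2ccccc2)c2ccccc2)N2C(=O)/C(=C/C(=O)c3ccccc3)[C@H]2S1(=O)=O` — 17500 nM
compound 3 `CCOC(=O)/C=C1/C(=O)N2[C@@H]1SC(C)(C)[C@@H]2C(=O)OC(c1ccccc1)c1ccccc1` — 7000 nM

Of the compounds shown here, three built on one shared core have been tested in a functional assay on A-375 cells (Homo sapiens) for cytotoxicity, read by MTT assay, with a stated time of 48 h; a lower number here means a stronger inhibitor, a higher number a weaker inhibitor. Compound 1 `CC(=O)/C=C1\C[C@H]2SC(C)(C)[C@H](C(=O)OC(c3ccccc3)c3ccccc3)N2C1=O` reaches only the limit of the assay, > 100000 nM. Compound 2 `CC1(C)[C@H](C(=O)OC(c2ccccc2)c2ccccc2)N2C(=O)/C(=C/C(=O)c3ccccc3)[C@H]2S1(=O)=O` gives 17500 nM in this assay. Compound 3 `CCOC(=O)/C=C1/C(=O)N2[C@@H]1SC(C)(C)[C@@H]2C(=O)OC(c1ccccc1)c1ccccc1` gives 7000 nM, the lowest of the two numbers obtained, with compound 2 standing beyond the scatter above it.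

Compound 4 `CC1(C)S[C@@H]2/C(=C\C(=O)c3ccccc3)C(=O)N2[C@H]1C(=O)OC(c1ccccc1)c1ccccc1` has not yet been measured. It differs from compound 3 in a single place: phenyl in place of ethoxy on a carbonyl carbon, so that the ethoxycarbonyl group of compound 3 becomes a benzoyl group. Among the compounds with values here, no step between measured compounds matches this change. Compound 2 also carries a benzoyl group, though on a different core, and it gives 17500 nM. Compound 1, with an acetyl group in place of it, sits at the limit of the assay. Compound 4 is therefore expected to be a weaker inhibitor than compound 3, by a step of a 2.9-fold higher number from compound 3 to compound 4 (0.46 log units; beyond the scatter). Compound 4 is estimated to give 20000 nM, within a range from 7000 nM to 60000 nM.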

Compound 4, half-maximal inhibitory concentration: 22800 nM
Compound 4: middle estimate off by 1.1-fold (0.06 log units), on the low side; measured number inside the range.
By their numbers in this assay, from the lowest: compound 3; then compounds 2 and 4 (each within the scatter of the next). At a limit, above all of these: compound 1.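

In this assay, within the data shown here, phenyl in place of ethoxy on a carbonyl carbon, which turns ethoxycarbonyl into benzoyl, gives the first measured step at this position: a 3.3-fold higher number from compound 3 to compound 4 (0.51 log units; beyond the scatter). The number obtained therefore depends on what this carbonyl carbon carries, and on this core the ethoxy group goes with the lower number and the phenyl group with the higher one. No measurement shown here gives a reason for this step.

As far as these compounds go, whether an amine, a hydroxyl group or a longer chain in place of ethoxy would lower the number further or raise it remains open. Also open, from the compounds shown here alone, is whether the same change from ethoxycarbonyl to benzoyl would give a step of similar size on the core of compound 2 or of compound 1.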